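Removing an Ethoxycarbonyl from Thiol-Bearing Amides

The compounds below may be only part of what the source reports. "The series", "measured", "known", "first", "only" and "open" are said of these compounds alone.

Compound 1, `Cc1c(C)c2c(c(C)c1O)CCC(C)(C(=O)NCCS)O2`: 93%
Compound 2, `CCOC(=O)C(CS)NC(=O)C1(C)CCc2c(C)c(O)c(C)c(C)c2O1`: 93%
Compound 3, `CCOC(=O)C(CS)NC(=O)/C=C/c1cc(C(C)(C)C)c(O)c(C(C)(C)C)c1`: 96%

All three were tested in a functional assay, with a stated time of 30 min, tested at 200 uM; on this read-out lower numbers stand for a weaker effect and higher numbers for a stronger effect at the one concentration tested. In this assay compound 1 gives 93%, compound 2 gives 93% and compound 3 gives 96%, so the three values lie within the scatter of one another.

Compound 2 and compound 1 share a core and differ by hydrogen in place of ethoxycarbonyl on a saturated chain carbon bound to an amide-type nitrogen and a saturated chain carbon; the step is no change at the digits printed from compound 2 to compound 1 (within the scatter). Compound 3 carries a different core, and the difference between the two cores is not broken down here.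

Compound 4, `CC(C)(C)c1cc(/C=C/C(=O)NCCS)cc(C(C)(C)C)c1O`, has not yet been measured. It differs from compound 3 by hydrogen in place of ethoxycarbonyl on a saturated chain carbon bound to an amide-type nitrogen and a saturated chain carbon, the same change at the same place as that from compound 2 to compound 1. The expected step in this assay is a number 1 percentage points lower from compound 3 to compound 4 (within the scatter), resting on no change at the digits printed from compound 2 to compound 1 (within the scatter). Compound 4 is therefore expected to give about 95%, estimated between 87% and 100%.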

Compound 4, a percentage reported as activity, at one concentration (the size of the read-out at that concentration, not a potency): 92%
Compound 4: the middle estimate sits 3 percentage points above what was measured; low and high end bracket the measured number.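

In this assay, taking away the ethoxycarbonyl on the second core gives a step that is a number 4 percentage points lower from compound 3 to compound 4 (within the scatter). Set beside the earlier case, the change carries from one core to the other with no difference that can be told apart: the same change on two cores in this assay, no change at the digits printed (within the scatter) from compound 2 to compound 1 and a number 4 percentage points lower (within the scatter) from compound 3 to compound 4, 4 percentage points apart, within the scatter of two such steps This shows only that the read-out stays within the scatter with or without the ethoxycarbonyl on these two cores at the one concentration tested; it gives no potency and sets no rule for other cores.

The compounds shown leave open how the read-out would respond to a hydroxyl or an amine in place of the sulfanyl group, or to a longer chain carrying it. On these data alone, whether the two cores would still match at lower concentrations also remains open.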